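From Pyridin-3-yl to Pyridin-4-yl: One Small Swap

This account rests on a few compounds, and the source may have more. Where it says the series, first, only, none or still open, it means among the compounds named here.

Of the compounds shown here, three that share a nitrile-bearing anilide portion have been tested in a functional assay on KG-1 cells (Homo sapiens) for cytotoxicity, read by luminescence and CellTiter-Glo, with a stated time of 3 days; on this read-out higher numbers stand for weaker inhibition and lower numbers for stronger inhibition. In this test, compound 2 `N#Cc1ccc(NC(=O)c2ccc(-c3cccnc3)cc2O)cc1` gives 7940 nM. Within the data shown here, the only other true number comes from compound 1 `N#Cc1ccc(NC(=O)c2cc(-c3ccncc3)ccc2O)cc1`, which gives 7990 nM, and these two values lie within the usual scatter of each other. Compound 3 `COc1cccc(O)c1C(=O)Nc1ccc(C#N)cc1` gives no true number, only a limit of the assay: > 10000 nM.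

The next compound to be tested is compound 4 `N#Cc1ccc(NC(=O)c2ccc(-c3ccncc3)cc2O)cc1`, which has the same atoms as compound 2, joined differently. The change is pyridin-4-yl in place of pyridin-3-yl on an aromatic carbon. That carbon is meta to a hydroxy group and para to a large group.

Among the measured compounds shown here, no measured pair of compounds isolates this kind of swap, so any forecast in this assay rests on thin evidence. Compound 1 also carries pyridin-4-yl, though on a differently arranged core, and its value of 7990 nM gives no hint of a large shift. The expected change is therefore none beyond the scatter, in neither direction, and the estimated step is a 1.1-fold lower number from compound 2 to compound 4 (0.05 log units; within the scatter). Compound 4 is expected to give about 7000 nM, with an estimated range of 3000 nM to 10000 nM.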

Compound 4, half-maximal inhibitory concentration: 8840 nM
Compound 4: middle estimate off by 1.3-fold (0.10 log units), on the low side; measured number inside the range.
By their numbers in this assay, from the lowest: compounds 2, 1 and 4 (each within the scatter of the next). At a limit, above all of these: compound 3.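

In this assay, among these compounds, the swap of pyridin-3-yl for pyridin-4-yl on this aromatic carbon gives a 1.1-fold higher number from compound 2 to compound 4 (0.05 log units; within the scatter), the first direct reading of this change. The two rings differ only in where their nitrogen sits, so at this position, and on this read-out, that difference has no effect that can be told from the usual scatter. Any weaker compound would have little room to show itself, because the test stops at a limit, the one that compound 3 reaches: the limit of > 10000 nM in this assay, at which 1 of the 4 values shown sits.

As far as these compounds go, both groups compared at this carbon are pyridine rings, so it stays open whether pyridin-2-yl, a plain phenyl ring, or a quite different group such as an amine or a carboxylic acid would shift the number beyond the scatter. This single pair also cannot say whether the same swap would behave alike on the core of compound 1, where the ring and the hydroxy group are arranged differently.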